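Ester for bromine on the diphenylurea of compound 3

The source may hold more compounds than are shown below. What is called first, only, known or untested is meant among the compounds shown, and "the series" means these compounds.

The three measured compounds share one core and differ at the end carrying the two phenyl groups or at the piperazine. Compound 1 `CCCCCN(CCCCC)C(=O)N1CCN(C(=O)N(c2ccccc2)c2ccccc2)C[C@H]1C(=O)O` gives 23 nM in an assay for inhibition of Type-2 angiotensin II receptor (Rattus norvegicus) (a higher number here means a weaker inhibitor, a lower number a stronger inhibitor), and compound 2 `CCCCCN(CCCCC)C(=O)N1CCN(C(=O)N(c2ccccc2)c2ccccc2)[C@H](CO)C1` gives 30 nM in this assay; these two numbers lie within the scatter of each other. Compound 3 `CCCCCN(CCCCC)C(=O)N1CCN(C(=O)N(c2ccccc2)c2cccc(Br)c2)[C@H](C(=O)O)C1` gives 0.6 nM in this assay, the lowest of the three numbers, and it stands apart from both others by margins beyond the scatter, so it is the strongest inhibitor among them.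

Compound 4 `CCCCCN(CCCCC)C(=O)N1CCN(C(=O)N(c2ccccc2)c2ccc(C(=O)OCC)cc2)[C@H](C(=O)O)C1` differs from compound 3 in one place: 4-(ethoxycarbonyl)phenyl in place of 3-bromophenyl on an amide-type nitrogen. Going by the values given here, no measured pair shows the effect of this change, so its size can only be estimated. Since compound 3 stands far from compounds 1 and 2, a return toward their numbers is plausible, and the expected step from compound 3 to compound 4 in this assay is a 13-fold higher number from compound 3 to compound 4 (1.12 log units; beyond the scatter), a rise beyond the scatter. Compound 4 is therefore expected to give about 8 nM in this assay, within a range from 1.5 nM to 40 nM.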

Compound 4, half-maximal inhibitory concentration: 35 nM
The estimate for compound 4 lay 4.4-fold (0.64 log units) below the measured number; low and high end bracket the measured number.
By their numbers in this assay, from the lowest: compound 3; then compounds 1, 2 and 4 (each within the scatter of the next).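

In this assay, 4-(ethoxycarbonyl)phenyl in place of 3-bromophenyl on an amide-type nitrogen gives a 58-fold higher number from compound 3 to compound 4 (1.77 log units; beyond the scatter), a large step and the only one measured at this position. It shows that, with the rest of the molecule unchanged, this one exchange of aryl group is enough to lose most of the strength of compound 3, so the number is highly sensitive to what this nitrogen carries. No measured finding accounts for the size of the step.

The step changes both the group on the phenyl ring and where it sits, and the compounds shown do not separate these two changes. Also open, as far as these compounds go, is how a carboxylic acid or an amine in place of the ester would affect the number.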